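The source may hold more compounds than are shown below. What is called first, only, known or untested is meant among the compounds shown, and "the series" means these compounds.

Two measured compounds share a core, shown by compound 1 `Fc1cccc(F)c1NC(=S)N/N=C\c1c[nH]c2ccccc12`. In an ADME assay on KB cells (Homo sapiens) for cytotoxicity, read by MTT assay, with a stated time of 44 h (on this read-out lower numbers stand for stronger inhibition and higher numbers for weaker inhibition), compound 1 gives > 100000 nM, which is a limit of the assay rather than a number. Compound 2 `Cc1ccc(NC(=S)N/N=C\c2c[nH]c3ccccc23)cc1` carries a 4-methylphenyl on the amide-type nitrogen. In this assay compound 2 gives > 100000 nM, again a limit and not a measured value. Where compound 2 stands can therefore only be bounded: it sits at the limit of > 100000 nM in this assay, at which 2 of the 2 values shown sit, so nothing is known of it beyond that it is no stronger than this boundary.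

Compound 3 `Cc1cccc(NC(=S)N/N=C\c2c[nH]c3ccccc23)c1` differs from compound 2 in one place: 3-methylphenyl in place of 4-methylphenyl on an amide-type nitrogen. No step between two measured compounds is available here, so the size of such a change cannot be read from the numbers shown. The two compounds that are measured both stop at the same limit, and the change is a small one, so the expected step from compound 2 to compound 3 is none beyond the usual scatter, a number no higher from compound 2 to compound 3 (the limit leaves the size open). In this assay compound 3 is thus expected to give about 100000 nM, within a range from 30000 nM to 300000 nM, most likely again reported only as a limit.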

Compound 3, half-maximal inhibitory concentration: > 100000 nM
Compound 3 was reported as a limit; the forecaster's own chance of this, stated with the estimate: 80%; the middle value sits exactly at the limit.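

Compound 2 and compound 3 both stop at a limit in this assay, so no step can be read for 3-methylphenyl in place of 4-methylphenyl on the amide-type nitrogen. The compounds shown leave open how weak any of them truly is, and whether any change to the shared core would give a measured number, as all sit at one boundary: the limit of > 100000 nM in this assay, at which 3 of the 3 values shown sit.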